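This account rests on a few compounds, and the source may have more. Where it says the series, first, only, none or still open, it means among the compounds named here.

Compound 1 `O=C(Cn1c(=O)c(/C=C\c2ccncc2)nc2ccccc21)Nc1ccc(F)cc1`: in a functional assay on PC-3 cells (Homo sapiens) for inhibition, read by MTT assay, with a stated time of 24 h (a lower number here means a stronger inhibitor, a higher number a weaker inhibitor), compound 1 gives 59900 nM.
Compound 2 `Cc1ccccc1NC(=O)Cn1c(=O)c(/C=C\c2ccncc2)nc2ccccc21`: in this assay compound 2 gives > 100000 nM, which is a limit of the assay and not a number.

Going by the values given here, of the two compounds measured so far, compound 2 stands at the limit of the assay, so only a floor is known for it, and nothing places it more exactly against compound 1. Among the compounds with values here, the single measured step, an at least 1.6-fold higher number from compound 1 to compound 2 (0.22 log units; that floor lies within the scatter), has a floor that sits within the usual scatter, so it does not establish a real change in either direction; what is known of that step rests on (the limit of > 100000 nM in this assay, at which 1 of the 2 values shown sits). The unmeasured compound 3 `O=C(Cn1c(=O)c(/C=C\c2ccncc2)nc2ccccc21)Nc1ccc(Cl)c(Cl)c1` differs from compound 2 in one place: 3,4-dichlorophenyl in place of 2-methylphenyl on an amide-type nitrogen. Within the data shown here, no measured step covers a change of this kind on the amide-type nitrogen, and the only comparison available is the one between compound 1 and compound 2, which is itself bounded by a limit. The step of an at least 1.2-fold lower number from compound 2 to compound 3 (0.09 log units; that floor lies within the scatter) is therefore an expectation without a measured anchor. Compound 3 is expected to give 80000 nM in this assay, within a range from 30000 nM to 250000 nM.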

Compound 3, half-maximal inhibitory concentration: > 100000 nM
Compound 3: no number, only a limit; the forecaster's own chance of this, stated with the estimate: 45%; at least 1.2-fold (0.09 log units) between middle value and limit.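

In this assay compound 3 gives > 100000 nM and this is a limit of the assay, not a number. With 3,4-dichlorophenyl on the amide-type nitrogen, the record shows an at least 1.6-fold higher number from compound 1 to compound 3 (0.22 log units; that floor lies within the scatter) and so establishes no real change in either direction, while the step between compound 2 and compound 3 cannot be read, as both values are limits. What is new is that a second replacement for 4-fluorophenyl at this position also gives no number, which leaves compound 1 as the only one of the three with a measured value, and the picture of this position rests largely on the assay's limit: the limit of > 100000 nM in this assay, at which 2 of the 3 values shown sit.

As far as these compounds go, how far compound 2 and compound 3 lie past that limit stays unknown, so they cannot be placed against each other or firmly against compound 1. Also open, from the compounds shown here alone, is whether a phenyl ring carrying a carboxylic acid or a dimethylamino group at this position would give a measurable number in this assay and so show a real change.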